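Swapping a sulfonamide for an amide in an isoindolinone series

A few compounds are considered here, and "the series" means these few. Any claim that something is new, unique, unknown or untested is made for them only; others in the source may bear on it.

Of the compounds shown here, two built on a shared core have been measured in an assay on RMS13 cells for displacement of a labelled ligand from Urotensin-2 receptor (Homo sapiens), read by scintillation proximity assay; a lower number here means a stronger inhibitor, a higher number a weaker inhibitor. Within the data shown here, compound 1, with structure `CCN1CCN(c2cccc3c2CN([C@H](CCCNS(=O)(=O)c2c[nH]cn2)c2ccc(OC)c(OC)c2)C3=O)CC1`, gives 25 nM in this assay, the lower of the two numbers so far. Compound 2, with structure `COc1ccc([C@@H](CCCN(C)S(=O)(=O)c2cccs2)N2Cc3c(cccc3N3CCN(C4CC4)CC3)C2=O)cc1OC`, gives 59 nM in this assay, a gap to compound 1 that lies beyond the usual scatter of repeat measurements. These two compounds differ in more than one place, so their pair says nothing about any single change.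

Compound 3, with structure `CCN1CCN(c2cccc3c2CN([C@H](CCCNC(=O)c2cccs2)c2ccc(OC)c(OC)c2)C3=O)CC1`, has not yet been measured. It differs from compound 1 in exactly one place: (thiophen-2-yl)carbonyl in place of (1H-imidazol-4-yl)sulfonyl on an amine nitrogen. Among the measured compounds shown here, no measured pair shows this particular exchange, so the direction of the step has to be guessed. Such a replacement is expected to cost somewhat, giving a weaker inhibitor, though the step from compound 1 to compound 3 is estimated as a 2.4-fold higher number from compound 1 to compound 3 (0.38 log units; beyond the scatter), only modestly beyond the scatter. On that basis compound 3 is expected to give about 60 nM in this assay, with a plausible range from 15 nM to 250 nM.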

Compound 3, inhibition constant: 18 nM
Estimate against measurement, compound 3: 3.3-fold (0.52 log units) above; low and high end bracket the measured number.
By their numbers in this assay, from the lowest: compounds 3 and 1 (each within the scatter of the next); then compound 2.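

Exchanging (1H-imidazol-4-yl)sulfonyl for (thiophen-2-yl)carbonyl on the amine nitrogen gives a 1.4-fold lower number from compound 1 to compound 3 (0.14 log units; within the scatter) in this assay, so the two compounds cannot be told apart in this assay. On this core, then, the position accepts a carbonyl in place of a sulfonyl and a thiophene ring in place of an imidazole ring with no step beyond the scatter, even though the entering group has 0 hydrogen-bond donors and the leaving group has 1. No measurement bears on why these two different groups give such similar numbers.

As far as these compounds go, the ring and its link to the nitrogen changed together, so what each contributes alone stays open, and compound 2 cannot settle this, since its thiophene sulfonyl comes with changes in other places. A (1H-imidazol-4-yl)carbonyl or (thiophen-2-yl)sulfonyl group on the same nitrogen of compound 1 would separate the two parts, while a small acetyl group there would ask whether a ring is needed at all.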